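This account rests on a few compounds, and the source may have more. Where it says the series, first, only, none or still open, it means among the compounds named here.

Measured compounds in a functional assay on cells for antagonist activity at C-C chemokine receptor type 1 (Homo sapiens), read by FLIPR and calcium flux; a lower number here means a stronger inhibitor, a higher number a weaker inhibitor:
compound 1 `Cc1c(C(=O)NCc2cccc(C(F)(F)F)c2)cnn1-c1ccc(Cl)cc1` gives 600 nM.
compound 2 `O=C(NCc1cccc(C(F)(F)F)c1)c1cnn(-c2ccc(Cl)cc2)c1CO` gives 1200 nM.
compound 3 `Nc1c(C(=O)NCc2cccc(C(F)(F)F)c2)cnn1-c1ccc(Cl)cc1` gives only the assay limit of > 3000 nM.

Compound 3 is thus the one of the three without a number, standing at the limit of > 3000 nM in this assay, at which 1 of the 3 values shown sits. Both measured steps toward it point upward: an at least 5.0-fold higher number from compound 1 to compound 3 (0.69 log units; beyond the scatter) and an at least 2.5-fold higher number from compound 2 to compound 3 (0.39 log units; beyond the scatter). The step between compound 1 and compound 2 is a 2.0-fold higher number from compound 1 to compound 2 (0.30 log units; within the scatter).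

Compound 4 `CN(C)c1c(C(=O)NCc2cccc(C(F)(F)F)c2)cnn1-c1ccc(Cl)cc1` keeps the shared core and the amide and carries dimethylamino in place of amino on an aromatic carbon. For the measured compounds named here, no measured step exchanges an amino for a dimethylamino, so the bearing of the measured steps is indirect: changes of the group on this ring carbon have shifted this assay by the sizes above, and the amino-bearing compound 3 sits beyond the limit. The direction for compound 4 is therefore open. Compound 4 is estimated at 3000 nM, between 800 nM and 10000 nM, with a fair chance that only a limit is again reported. As a step this estimate means a number no higher from compound 3 to compound 4 (the limit leaves the size open), an expected change not beyond the scatter.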

Compound 4, half-maximal inhibitory concentration: > 3000 nM
Compound 4 gave a limit, no number; the forecaster's own chance of this, stated with the estimate: 55%; the middle value lies on the limit itself.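

In this assay, dimethylamino on this aromatic carbon, next to the ring nitrogen, gives no readable value, and compound 4 ends at a limit. Against the compounds with numbers, the change is an at least 5.0-fold higher number from compound 1 to compound 4 (0.69 log units; beyond the scatter) and an at least 2.5-fold higher number from compound 2 to compound 4 (0.39 log units; beyond the scatter), so both nitrogen-linked groups shown here fall short of methyl and hydroxymethyl, and dimethylamino does not restore a number. The step between compound 3 and compound 4 cannot be read, as both sit at the same limit: the limit of > 3000 nM in this assay, at which 2 of the 4 values shown sit.

Going by these compounds, how far either compound lies past that limit remains open, so the effect of replacing the amino hydrogens with methyl groups cannot be sized. Also open, on these data alone, is whether ethyl, methoxy or chlorine on this ring carbon would match or improve on compound 1, at 600 nM.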